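The compounds below may be only part of what the source reports. "The series", "measured", "known", "first", "only" and "open" are said of these compounds alone.

For the measured compounds named here, in a functional assay on HCT-116 cells (Homo sapiens) for cytotoxicity, read by MTT assay, with a stated time of 72 h (on this read-out lower numbers stand for stronger inhibition and higher numbers for weaker inhibition), two compounds have numbers so far. Compound 1 (`O=S(=O)(c1ccc(F)cc1)c1nc2ccccc2nc1N1CCCC1`) gives 20600 nM, while compound 2 (`COc1ccc(S(=O)(=O)c2nc3ccccc3nc2N2CCC(O)CC2)cc1`) gives 4690 nM, the lower of the two and separated from the other by more than the usual scatter. These two compounds differ in more than one place, so their gap cannot be assigned to a single change. Compound 3 (`O=S(=O)(c1ccc(F)cc1)c1nc2ccccc2nc1N1CCC(O)CC1`) departs from compound 2 in one place: fluoro in place of methoxy on an aromatic carbon, para to a large group. Going by the values given here, no measured pair shows this change alone. The 4-fluorophenyl is also carried by compound 1 at 20600 nM, which points to a modest rise in the number, of about the size of the scatter. The expected change is a 1.7-fold higher number from compound 2 to compound 3 (0.23 log units; within the scatter). For compound 3 the estimated value is 8000 nM, with an expected range of 3000 nM to 20000 nM.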

Compound 3, half-maximal inhibitory concentration: 1340 nM
Compound 3: middle estimate off by 6.0-fold (0.78 log units), on the high side, and the stated range ends above it.
By their numbers in this assay, from the lowest: compound 3; then compound 2; then compound 1.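

Fluoro in place of methoxy on an aromatic carbon, para to a large group, gives a 3.5-fold lower number from compound 2 to compound 3 (0.54 log units; beyond the scatter) in this assay with 4-hydroxypiperidin-1-yl held fixed, so this position responds to the change beyond the scatter and the number falls with 4-fluorophenyl. With 4-fluorophenyl held fixed, 4-hydroxypiperidin-1-yl in place of pyrrolidin-1-yl gives a 15-fold lower number from compound 1 to compound 3 (1.19 log units; beyond the scatter) in a large step, which ties the high number of compound 1 to the pyrrolidin-1-yl group and not to the fluoro. Nothing available explains either step.

The compounds shown leave open whether chloro, trifluoromethyl or a nitrile at this position would follow fluoro or methoxy. They also leave open how much of the second step rests on the hydroxyl, since a plain piperidine or a morpholine does not appear among them.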